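Swapping chloro for acetyl on a cyanoguanidine aryl ring

The source may hold more compounds than are shown below. What is called first, only, known or untested is meant among the compounds shown, and "the series" means these compounds.

The measured compounds:
- compound 1, `CC1(C)Oc2ccc(C#N)cc2[C@@H](/N=C(\NC#N)Nc2ccc(Cl)cc2)[C@@H]1O`: 1800 nM
- compound 2, `CC1(C)Oc2ccc(C#N)cc2[C@@H](NC(=O)Nc2ccccc2)[C@@H]1O`: 800 nM
- compound 3, `CC1(C)Oc2ccc(C#N)cc2[C@@H](n2c(O)nc3ccccc32)[C@@H]1O`: 41000 nM

All three share the same core and differ in the group attached to its amine-bearing carbon. In a functional assay (aorta) with Rattus norvegicus as the target (a lower number here means a stronger inhibitor, a higher number a weaker inhibitor), compound 1 gives 1800 nM, which places it second highest of the three numbers. Compound 2 sits nearest, with a lower number that lies beyond the scatter, while compound 3 sits furthest, with a much higher number that is also beyond the scatter.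

Compound 4, `CC(=O)c1ccc(N/C(=N/[C@@H]2c3cc(C#N)ccc3OC(C)(C)[C@H]2O)NC#N)cc1`, is not yet measured. It differs from compound 1 in one place: acetyl in place of chloro on an aromatic carbon of a six-membered aromatic ring of carbon only, para to a large group. Among the measured compounds shown here, no pair among the measured compounds shows this change, so no step can be read off for it. With nothing in the measured set to anchor the direction, the expected step of a 1.4-fold higher number from compound 1 to compound 4 (0.14 log units; within the scatter) is small, likely within the scatter, with a slight lean towards a higher number. For compound 4 in this assay the estimate is 2500 nM, with a range from 600 nM to 10000 nM.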

Compound 4, half-maximal inhibitory concentration: 21000 nM
Estimate against measurement, compound 4: 8.4-fold (0.92 log units) below, and the stated range ends below it.
By their numbers in this assay, from the lowest: compound 2; then compound 1; then compounds 4 and 3 (each within the scatter of the next).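

In this assay, replacing chloro with acetyl on the aromatic carbon para to a large group gives a 12-fold higher number from compound 1 to compound 4 (1.07 log units; beyond the scatter), a large step for a change in a single substituent. Until now, nothing showed whether this position tolerates change, and this pair shows that the substituent here can strongly affect the read-out, at least on the cyanoguanidine series represented by compound 1 and compound 4. The data contain no measurement that explains this loss of inhibition, so the reason for it remains unknown.

Acetyl differs from chloro in several ways at once: it has more heavy atoms, a double bond outside the aromatic ring and a hydrogen-bond acceptor, and this single pair cannot show which of these differences matters. Compounds carrying a fluorine, a methyl group, a methoxy group or an amine on this same aromatic carbon would help to separate those differences and show whether the step depends on the acetyl carbonyl or on the size of the group.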